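Compound 1 and the carbonyl step

The compounds below may be only part of what the source reports. "The series", "measured", "known", "first", "only" and "open" are said of these compounds alone.

Going by the values given here, in a functional assay on HepG2 cells (Homo sapiens) for antiproliferative activity, read by MTT assay (on this read-out lower numbers stand for stronger inhibition and higher numbers for weaker inhibition), compound 1 (`CC(=O)/C=C/c1ccc(OC2CCCC2)cc1`) gives 27300 nM as the lower of the two numbers so far. Compound 2 (`O=C1CCCCC/C1=C\c1ccc(OC2CCCC2)cc1`) gives 71300 nM as the higher, a gap beyond the scatter. Compound 3 (`Cc1ccc(C(=O)/C=C/c2ccc(OC3CCCC3)cc2)cc1`) has 4-methylphenyl in place of methyl on a carbonyl carbon. Among the compounds with values here, no measured pair shows this change, so the estimate carries wide uncertainty. A modest fall in the number in this assay is expected, slightly beyond the scatter. The estimated move is a 2.3-fold lower number from compound 1 to compound 3 (0.36 log units; beyond the scatter) and remains an expectation only. Compound 3 is expected at 12000 nM (estimated range 4000 nM to 35000 nM).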

Compound 3, half-maximal inhibitory concentration: 20000 nM
Compound 3: the middle estimate sits 1.7-fold (0.22 log units) below what was measured; low and high end bracket the measured number.
By their numbers in this assay, from the lowest: compounds 3 and 1 (each within the scatter of the next); then compound 2.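

On the carbonyl carbon whose other neighbour is the double-bonded chain carbon, 4-methylphenyl in place of methyl gives a 1.4-fold lower number from compound 1 to compound 3 (0.14 log units; within the scatter) in this assay, so this place accepts the much larger group with no change that can be told from the scatter. Going by these compounds alone, neither compound 1 nor compound 2 carries an aromatic ring on this carbon, so this is the first reading of such a group there. Nothing measured on these compounds explains the size of this step.

The compounds shown leave open how a phenyl without the methyl, or one carrying an amine or a carboxylic acid in its place, would read on this carbon.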